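This account rests on a few compounds, and the source may have more. Where it says the series, first, only, none or still open, it means among the compounds named here.

Among the compounds with values here, compound 2, with the structure `O=c1ncn(Cc2c(F)cc(F)cc2F)c2ccc(Oc3cccc(-c4ccc5[nH]cnc5c4)c3C(F)(F)F)cc12`, stands at the lower end of the two numbers so far: in a physicochemical assay for lipophilicity, at pH 7.4 (on this read-out lower numbers stand for lower lipophilicity and higher numbers for higher lipophilicity), compound 2 gives 4.7, while compound 1, with the structure `O=c1ncn(Cc2c(F)cc(F)cc2F)c2ccc(Oc3cccc(-c4ccc5[nH]ccc5c4)c3C(F)(F)F)cc12`, gives 5.1. Within the data shown here, the one measured step between them, a number 0.40 log units lower from compound 1 to compound 2 (beyond the scatter), came from swapping the indole for a benzimidazole and lies beyond the scatter.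

Compound 3, with the structure `O=c1ncn(Cc2c(F)cc(F)cc2F)c2ccc(Oc3cccc(-c4ccc5cc[nH]c5c4)c3C(F)(F)F)cc12`, is not yet measured. It differs from compound 2 in one place: 1H-indol-6-yl in place of 1H-benzimidazol-5-yl on an aromatic carbon. This is close to a reversal of the measured step. The benzimidazole leaves and an indole enters, though the indole is now attached through a different ring position than in compound 1.

Given that the step from compound 1 to compound 2 lowered this assay by a number 0.40 log units lower from compound 1 to compound 2 (beyond the scatter), the return to an indole is expected to raise it by about the same amount, so a step of a number 0.40 log units higher from compound 2 to compound 3 (beyond the scatter) is estimated. Compound 3 is therefore expected to read 5.1, with a range from 4.7 to 5.5.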

Compound 3, distribution coefficient: 5
Beside the measured number, compound 3's estimate is 0.10 log units above it; measured number inside the range.
By their numbers in this assay, from the lowest: compounds 2, 3 and 1 (each within the scatter of the next, the first and the last beyond it).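

In this assay, replacing 1H-indol-5-yl with 1H-indol-6-yl gives a number 0.10 log units lower from compound 1 to compound 3 (within the scatter), so at this aromatic carbon, ortho to a trifluoromethyl group, the read-out does not separate these two indole attachments. Replacing 1H-benzimidazol-5-yl with 1H-indol-6-yl gives a number 0.30 log units higher from compound 2 to compound 3 (within the scatter), whereas the earlier indole-to-benzimidazole change gave a number 0.40 log units lower from compound 1 to compound 2 (beyond the scatter), so the indole attached this new way cannot be told apart from either of two compounds that can be told apart from each other. No measurement here offers an explanation for these numbers.

With only three compounds, all carrying a fused ring pair at this carbon, the shown results leave open how far the number could move with a group of another kind here, such as a carboxylic acid, an amine or a plain phenyl ring. Within the data shown here, they also leave open whether benzimidazole and indole would differ beyond the scatter at every attachment, since the only such comparison beyond it involves 1H-indol-5-yl.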